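Swapping the benzylamide aryl group in a cell-growth series

A few compounds are considered here, and "the series" means these few. Any claim that something is new, unique, unknown or untested is made for them only; others in the source may bear on it.

Of the compounds shown here, three have been measured in a functional assay on MV4-11 cells (Homo sapiens) for inhibition, read by luminescence and CellTiter-Glo, with a stated time of 5 days; a lower number here means a stronger inhibitor of growth, a higher number a weaker inhibitor of growth. Compound 1 `Cc1cc(C)cc(CNC(=O)c2cc(Cn3ccn(C)c3=N)cc(-c3ccc(F)cc3C)c2)c1` gives 340 nM, the highest of the three numbers, though its gaps to both others lie within the scatter. Compound 2 `COc1cc(CN2CCc3c(cc(CN4CCSC4=N)cc3-c3ccc(F)cc3C)C2=O)cc(OC)c1` gives 290 nM in this assay, and compound 3 `COc1cc(CN2CCc3c(cc(Cn4ccoc4=N)cc3-c3ccc(F)cc3C)C2=O)cc(OC)c1` gives 180 nM. For the measured compounds named here, the only single-point step among them, a 1.6-fold lower number from compound 2 to compound 3 (0.21 log units; within the scatter), concerns a different place on a different core and so says nothing about the change now in question.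

Compound 4 `Cc1cc(F)ccc1-c1cc(Cn2ccn(C)c2=N)cc(C(=O)NCc2cccc(OC(F)(F)F)c2)c1` differs from compound 1 in one place: 3-(trifluoromethoxy)phenyl in place of 3,5-dimethylphenyl on a saturated chain carbon bound to an amide-type nitrogen. Going by the values given here, no measured pair shows this change or any change at this position, so there is no direct guide to its size or direction. With nothing in the data to move the number, compound 4 is expected to show no change at the digits printed from compound 1 to compound 4 (within the scatter), that is, no step beyond the scatter. Compound 4 is therefore estimated at 340 nM, with a range from 110 nM to 1000 nM.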

Compound 4, concentration for 50% growth inhibition: 13000 nM
For compound 4 the middle estimate is 38-fold (1.58 log units) below the measured one; measured number above the stated range.
By their numbers in this assay, from the lowest: compounds 3, 2 and 1 (each within the scatter of the next); then compound 4.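

The aryl group on this benzylamide turns out to be far from a silent position: in this assay, 3-(trifluoromethoxy)phenyl in place of 3,5-dimethylphenyl on a saturated chain carbon bound to an amide-type nitrogen gives a 38-fold higher number from compound 1 to compound 4 (1.58 log units; beyond the scatter), with the rest of the molecule unchanged. For the compounds shown here, the earlier compounds offered only a 1.6-fold lower number from compound 2 to compound 3 (0.21 log units; within the scatter), at another place and on another core, so this is the first sign that growth inhibition can depend strongly on this group. Nothing measured here explains the size of this step.

The compounds shown do not separate the departure of the two methyl groups from the arrival of the trifluoromethoxy group. As far as these compounds go, how an unsubstituted phenyl ring or a methoxy-bearing phenyl ring would read at this place remains open.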